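This account rests on a few compounds, and the source may have more. Where it says the series, first, only, none or still open, it means among the compounds named here.

Compound 1 `CNC(=O)c1ccccc1Oc1nc(Nc2ccccc2F)ncc1Br` reaches only the limit of > 50000 nM in a functional assay on U-937 cells (Homo sapiens) for antiproliferative activity, read by MTT assay, with a stated time of 24 h; a higher number here means a weaker inhibitor, a lower number a stronger inhibitor; this is a limit, not a number.
Compound 2 `CNC(=O)c1ccccc1Oc1nc(Nc2ccc(C)cc2C)ncc1Br` gives 49600 nM in this assay.
Compound 3 `CNC(=O)c1ccccc1Oc1nc(Nc2cccc(C(F)(F)F)c2)ncc1Br` gives 45500 nM in this assay.

Among the measured compounds shown here, compound 3 thus sits within the usual scatter of compound 2, and the only other value shown is the limit of compound 1. For the measured compounds named here, the single measured step, a number no higher from compound 1 to compound 2 (the limit leaves the size open), alters the group on a nitrogen on an aromatic ring, but its size cannot be read because one end is the limit (the limit of > 50000 nM in this assay, at which 1 of the 3 values shown sits). Compound 4 `CNC(=O)c1ccccc1Oc1nc(Nc2cccc(OC)c2)ncc1Br` differs from compound 3 by methoxy in place of trifluoromethyl on an aromatic carbon. Going by the values given here, no measured step with a readable size covers such a change, so nothing here points beyond the scatter; compound 4 is expected to show a 1.1-fold higher number from compound 3 to compound 4 (0.02 log units; within the scatter), no step beyond the scatter. For compound 4 the estimate in this assay is 48000 nM, ranging from 22000 nM to 100000 nM, with a fair chance that only a limit is reported.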

Compound 4, half-maximal inhibitory concentration: 24300 nM
The estimate for compound 4 lay 2.0-fold (0.30 log units) above the measured number; the measured number falls inside the stated range.
By their numbers in this assay, from the lowest: compounds 4, 3 and 2 (each within the scatter of the next, the first and the last beyond it). At a limit, above all of these: compound 1.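

In this assay, methoxy in place of trifluoromethyl on this aromatic carbon gives a 1.9-fold lower number from compound 3 to compound 4 (0.27 log units; within the scatter), so this change alone does not separate the two compounds. A separation beyond the scatter appears only with the wider changes of the group on the nitrogen: a 2.0-fold lower number from compound 2 to compound 4 (0.31 log units; beyond the scatter), and an at least 2.0-fold lower number from compound 1 to compound 4 (0.31 log units; beyond the scatter). Compound 1 stands at a limit, not a number, so the last step gives only a bound: the limit of > 50000 nM in this assay, at which 1 of the 4 values shown sits.

The compounds shown leave open how an amine or a carboxylic acid on this aromatic carbon would read. They also leave open whether a longer chain in place of methoxy would carry the number further down.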